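The source may hold more compounds than are shown below. What is called first, only, known or untested is meant among the compounds shown, and "the series" means these compounds.

Measured in an ADME assay on L02 cells (Homo sapiens) for cytotoxicity, read by CCK-8 assay, with a stated time of 6 days; a higher number here means a weaker inhibitor, a lower number a stronger inhibitor:
- compound 1 `C[C@@H](Cn1ccc(-c2ccc(C#N)c(Cl)c2)n1)NC(=O)c1ccccc1F`: "not determined" (no result reported)
- compound 2 `COC(=O)/C=C/C(=O)N[C@@H](C)Cn1ccc(-c2ccc(C#N)c(Cl)c2)n1`: "not determined" (no result reported)
- compound 3 `C[C@@H](Cn1ccc(-c2ccc(C#N)c(Cl)c2)n1)Nc1cccnc1`: > 30000 nM

Among the measured compounds shown here, compound 3 is the only compound here with a reported result, and its > 30000 nM is a limit of the assay, not a number. For the measured compounds named here, the series therefore offers no exact value and no measured step: the limit of > 30000 nM in this assay, at which 1 of the 3 values shown sits. In compound 4 `C[C@@H](Cn1ccc(-c2ccc(C#N)c(Cl)c2)n1)Nc1ncnc2nc[nH]c12`, the pyridin-3-yl group on the amine nitrogen is replaced: a group of 9 heavy atoms (5 carbon, 4 nitrogen; one five-membered aromatic ring with 2 hetero atoms, one six-membered aromatic ring with 2 hetero atoms) in place of a group of 6 heavy atoms (5 carbon, 1 nitrogen; one six-membered aromatic ring with 1 hetero atom), on an amine nitrogen.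

Going by the values given here, with no measured step to scale from, the size of this change in this assay can only be judged loosely. No step beyond the scatter is the most likely expectation, with any real shift expected towards stronger inhibition, since a limit leaves room in that direction only as far as can be seen. The expected change is an at least 1.2-fold lower number from compound 3 to compound 4 (0.07 log units; that floor lies within the scatter). For compound 4 the estimated value is 25000 nM, with an expected range of 8000 nM to 60000 nM.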

Compound 4, half-maximal inhibitory concentration: 27900 nM
Compound 4: middle estimate off by 1.1-fold (0.05 log units), on the low side, and the stated range covers the measured number.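

In this assay compound 4 gives 27900 nM, an exact number at this position on the amine nitrogen, where the series had offered none. Compound 3 gives > 30000 nM, which is a limit of the assay and not a number. Replacing pyridin-3-yl with the larger group bearing a five-membered and a six-membered aromatic ring gives an at least 1.0-fold lower number from compound 3 to compound 4 (0.03 log units; that floor lies within the scatter), so the shown change, which also adds a hydrogen-bond donor, brings no step beyond the scatter, though only a floor can be read: the limit of > 30000 nM in this assay, at which 1 of the 4 values shown sits.

Still open, as far as these compounds go, is how a piperidine or a carboxylic acid-bearing chain on this amine nitrogen would read in this assay. The steps to the amides compound 1 and compound 2 cannot be read, as neither has a number.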